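The compounds below may be only part of what the source reports. "The series", "measured", "known", "first", "only" and "open" are said of these compounds alone.

Three compounds were measured in an ADME assay on the whole organism with Oryza sativa as the target, tested at 0.1 uM; a higher number here means a weaker effect of the compound at the concentration tested, a lower number a stronger effect:

Compound 1 `C[C@H](NC(=O)Nc1ccc(C(C)(C)C)cc1)c1ccccc1`: 100%
Compound 2 `CCCCc1ccc(NC(=O)N[C@@H](C)c2ccccc2)cc1`: 98%
Compound 3 `CC(=O)c1ccc(NC(=O)N[C@@H](C)c2ccccc2)cc1`: 99%

Compound 3 sits between the other two on these numbers, with a number 1 percentage points lower from compound 1 to compound 3 (within the scatter) and a number 1 percentage points higher from compound 2 to compound 3 (within the scatter); all three values lie within the usual scatter of one another. Compound 4 `C[C@H](NC(=O)Nc1ccc(F)cc1)c1ccccc1` is made from compound 3 by a change at the same aromatic carbon that was varied among the first three compounds: fluoro in place of acetyl on an aromatic carbon. Every measured step at this position, a number 2 percentage points lower from compound 1 to compound 2 (within the scatter), a number 1 percentage points lower from compound 1 to compound 3 (within the scatter) and a number 1 percentage points higher from compound 2 to compound 3 (within the scatter), stayed within the scatter, so exchanging the group here once more is expected to give no step beyond the scatter in this assay. For compound 4 the expected value is 99%, between 90% and 100%, a step of no change at the digits printed from compound 3 to compound 4 (within the scatter) that is estimated to be within the scatter.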

Compound 4, a percentage reported as activity, at one concentration (the size of the read-out at that concentration, not a potency): 96%
For compound 4 the middle estimate is 3 percentage points above the measured one, and the stated range covers the measured number.
By their numbers in this assay, from the lowest: compounds 4, 2, 3 and 1 (each within the scatter of the next).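

Fluoro in place of acetyl (a number 3 percentage points lower from compound 3 to compound 4 (within the scatter)), in place of butyl (a number 2 percentage points lower from compound 2 to compound 4 (within the scatter)) and in place of tert-butyl (a number 4 percentage points lower from compound 1 to compound 4 (within the scatter)) all stay within the scatter in this assay. So this position now spans a group of a single heavy atom as well as larger ones, and the read-out still shows no step beyond the scatter. No available data explain why these numbers stay so close.

From the compounds shown here alone, whether an amine, a carboxylic acid or a much longer chain at this aromatic carbon would give a clear step remains open. So does whether changes elsewhere on the shared core would.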